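Furan-2-yl for naphthalen-2-yl: cytotoxicity expected unchanged

The source may hold more compounds than are shown below. What is called first, only, known or untested is meant among the compounds shown, and "the series" means these compounds.

The three measured compounds share one core, a tertiary amide bearing an isopropyl group, a benzyl arm carrying a six-carbon chain through an ether, and a biaryl on the carbonyl side. Compound 1 `CC(C)N(Cc1cccc(OCCCCCC(=O)O)c1)C(=O)c1ccc(-c2cccc(O)c2)cc1` carries a hydroxy group on its distal ring. In an ADME assay on BJ cells (Homo sapiens) for cytotoxicity, read by CellTiter-Glo and resazurin assay, with a stated time of 72 h (a lower number here means that less compound is needed, a higher number that more compound is needed for the effect), compound 1 gives > 26000 nM, a limit of the assay and not a number. Compound 2 `CC(C)N(Cc1cccc(OCCCCCC(=O)O)c1)C(=O)c1ccc(-c2cccc(S(C)(=O)=O)c2)cc1` differs by methylsulfonyl in place of hydroxy on an aromatic carbon. In this assay compound 2 gives > 26000 nM, again a limit. The step that the two limits leave unreadable from compound 1 to compound 2 therefore cannot be read. Compound 3 `CCOC(=O)CCCCCOc1cccc(CN(C(=O)c2ccc(-c3ccc4ccccc4c3)cc2)C(C)C)c1` carries the ester of the chain acid and a naphthalen-2-yl. In this assay compound 3 gives > 26000 nM, likewise a limit. Compound 3 thus stands with the others at the limit of > 26000 nM in this assay, at which 3 of the 3 values shown sit.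

Compound 4 `CCOC(=O)CCCCCOc1cccc(CN(C(=O)c2ccc(-c3ccco3)cc2)C(C)C)c1` differs from compound 3 by furan-2-yl in place of naphthalen-2-yl on an aromatic carbon. Among the measured compounds shown here, no measured step touches this ring; the one step recorded is unreadable. Nothing in the data points to a change beyond the scatter, so compound 4 is expected to sit at the limit as well, with a step that the limit leaves unreadable from compound 3 to compound 4. The estimate for compound 4 is 40000 nM, in a range from 20000 nM to 100000 nM.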

Compound 4, half-maximal effective concentration: > 26000 nM
Compound 4: a limit, no number (the forecaster's own chance of this, stated with the estimate: 85%); the middle value does not contradict the limit.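

Compound 4, like compound 3, gives only a limit in this assay, so the step between compound 3 and compound 4 cannot be read. The compounds shown leave open how far any of these changes would shift the effective concentration, as all stand together: the limit of > 26000 nM in this assay, at which 4 of the 4 values shown sit.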